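The source may hold more compounds than are shown below. What is called first, only, known or untested is meant among the compounds shown, and "the series" means these compounds.

Measured compounds:

Compound 1 `O=[N+]([O-])c1ccccc1NC(CO)CO`. In a functional assay on SUNE1 cells (Homo sapiens) for cytotoxicity (on this read-out higher numbers stand for weaker inhibition and lower numbers for stronger inhibition), compound 1 gives > 100000 nM, which is a limit of the assay and not a number.
Compound 2 `O=[N+]([O-])c1ccc(NC(CO)CO)c([N+](=O)[O-])c1`. In this assay compound 2 gives > 100000 nM, again a limit of the assay.
Compound 3 `O=[N+]([O-])c1cc(C(F)(F)F)ccc1NC(CO)CO`. In this assay compound 3 gives > 100000 nM, likewise a limit.

Compound 2 thus stands at the limit of > 100000 nM in this assay, at which 3 of the 3 values shown sit, and nothing in the numbers places it above or below its two neighbours. Compound 4 `O=[N+]([O-])c1ccc(NC(CO)CO)c(C(F)(F)F)c1` arises from compound 2 by trifluoromethyl in place of nitro on an aromatic carbon. The measured step that matches this change most closely is a step that the two limits leave unreadable from compound 2 to compound 3; the two other steps, a step that the two limits leave unreadable from compound 1 to compound 2 and a step that the two limits leave unreadable from compound 1 to compound 3, are equally unreadable. With every measured value a limit, no size or direction can be taken from them for this assay. The expectation for compound 4 is therefore simply that it also reaches only the limit, with an estimated value of 100000 nM in a range from 30000 nM to 300000 nM. The step this estimate implies, a number no higher from compound 2 to compound 4 (the limit leaves the size open), is expected to be none beyond the scatter.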

Compound 4, half-maximal inhibitory concentration: > 100000 nM
Compound 4 ended at the assay's limit; the forecaster's own chance of this, stated with the estimate: 85%; the middle value lies on the limit itself.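

In this assay, for the compounds shown here, compound 2 and compound 4 both stop at a limit of the assay, so no step between them can be read. The compounds shown leave open how strongly each one inhibits, and whether any change to the shared core gives a readable value.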